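This account rests on a few compounds, and the source may have more. Where it says the series, first, only, none or still open, it means among the compounds named here.

Compound 1 `COc1ccc(-c2cc(NNC(=O)Nc3cc(Cl)nc(Cl)c3)nc3c2cnn3C)cc1` has the lowest of the three numbers recorded in an assay on isolated protein for binding affinity to sphingosine 1-phosphate receptor 2 (Homo sapiens), read by surface plasmon resonance; on this read-out higher numbers stand for weaker binding and lower numbers for tighter binding; in this assay compound 1 gives 520 nM. Its nearest neighbour is compound 3 `CC(C)c1cc(NNC(=O)Nc2cc(Cl)nc(Cl)c2)nc2c1cnn2C`, which in this assay gives 780 nM; the step of a 1.5-fold higher number from compound 1 to compound 3 (0.18 log units; within the scatter) lies within the scatter. The furthest is compound 2 `CCCc1cc(NNC(=O)Nc2cc(Cl)nc(Cl)c2)nc2c1cnn2C`, which in this assay gives 1400 nM; the step of a 2.7-fold higher number from compound 1 to compound 2 (0.43 log units; beyond the scatter) is beyond the scatter. Between the two alkyl analogues the step of a 1.8-fold lower number from compound 2 to compound 3 (0.25 log units; within the scatter) is within the scatter.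

Compound 4 `COc1ccc(-c2cc(NNC(=O)Nc3cc(Br)nc(Br)c3)nc3c2cnn3C)cc1` is not yet measured. It differs from compound 1 by 2,6-dibromopyridin-4-yl in place of 2,6-dichloropyridin-4-yl on an amide-type nitrogen. None of the three measured steps bears on this change: each of them alters the group on the aromatic carbon of the shared core, and the halogenated pyridinyl on the amide-type nitrogen is kept the same throughout. For the measured compounds named here, since there is no measured step at that place, the expectation rests only on compound 1 itself, and the step of no change at the digits printed from compound 1 to compound 4 (within the scatter) is expected to stay within the scatter in either direction. On that basis compound 4 is estimated to give 520 nM in this assay, with a range from 200 nM to 1400 nM.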

Compound 4, dissociation constant: 6320 nM
For compound 4 the middle estimate is 12-fold (1.08 log units) below the measured one; measured number outside the range, above it.
By their numbers in this assay, from the lowest: compounds 1, 3 and 2 (each within the scatter of the next, the first and the last beyond it); then compound 4.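

In this assay, for the compounds shown here, the halogenated pyridinyl on the amide-type nitrogen, held constant in the earlier compounds, turns out to be a sensitive part of the series: a 12-fold higher number from compound 1 to compound 4 (1.08 log units; beyond the scatter) is a large step, beyond the scatter, and it points to weaker binding. The change is only 2,6-dibromopyridin-4-yl in place of 2,6-dichloropyridin-4-yl, with the heavy-atom count, ring, and hydrogen-bond donor and acceptor counts all the same, so the two chlorine atoms cannot be exchanged for bromine without a clear cost on this core. This step also exceeds the largest one seen at the aromatic carbon of the shared core, a 2.7-fold higher number from compound 1 to compound 2 (0.43 log units; beyond the scatter) and nothing available explains why the exchange has this effect.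

Going by these compounds, it remains open whether binding falls steadily from chlorine to bromine or whether chlorine is a particular optimum, which the corresponding fluoro, methyl or trifluoromethyl analogues on the pyridine would help to settle. Also unresolved is whether the same exchange would carry the same cost with propyl or isopropyl on the core, as in compound 2 and compound 3, or whether it depends on the 4-methoxyphenyl group.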